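Trading the Bromophenyl Arm for Ethyl at the Sulfur Chain

The source may hold more compounds than are shown below. What is called first, only, known or untested is meant among the compounds shown, and "the series" means these compounds.

Compound 1, `Cc1cc(N2CC[C@@H](C)[C@@H](N(C)c3ncnc4[nH]ccc34)C2)n2nc(SCc3ccccc3Br)nc2n1`: 27000 nM
Compound 2, `Cc1cc(N2CC[C@@H](C)[C@@H](N(C)c3ncnc4[nH]ccc34)C2)n2nc(SCc3csc4ccc(Cl)cc34)nc2n1`: > 100000 nM (a limit of the assay)
Compound 3, `CCCSc1nc2nc(C)cc(N3CC[C@@H](C)[C@@H](N(C)c4ncnc5[nH]ccc45)C3)n2n1`: not yet measured

Within the data shown here, in a functional assay on MGC-803 cells (Homo sapiens) for inhibition, read by MTT assay, with a stated time of 72 h (a lower number here means a stronger inhibitor, a higher number a weaker inhibitor), compound 1 gives 27000 nM, the only finished number among the two measured compounds. Compound 2 reaches only > 100000 nM, which is a limit of the assay rather than a number. Among the measured compounds shown here, the one measured step, an at least 3.7-fold higher number from compound 1 to compound 2 (0.56 log units; beyond the scatter), rests on (the limit of > 100000 nM in this assay, at which 1 of the 2 values shown sits), so its true size is unknown beyond its lower bound.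

Compound 3 carries the change (ethyl in place of 2-bromophenyl on a saturated chain carbon bound to a sulfur). For the measured compounds named here, no measured step removes the aromatic ring at this position; the step from compound 1 to compound 2 only shows that a different, larger ring at the same place gave a weaker number. With compound 1 already weak, an ethyl group in its place is expected to give a weaker compound 3, roughly a 2.2-fold higher number from compound 1 to compound 3 (0.35 log units; beyond the scatter). Compound 3 is therefore estimated at 60000 nM, within 20000 nM to 200000 nM.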

Compound 3, half-maximal inhibitory concentration: 15500 nM
Beside the measured number, compound 3's estimate is 3.9-fold (0.59 log units) above it, outside the stated range (below it).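

In this assay, ethyl in place of 2-bromophenyl on a saturated chain carbon bound to a sulfur gives a 1.7-fold lower number from compound 1 to compound 3 (0.24 log units; within the scatter), so compound 1 and compound 3 cannot be told apart, and the six-membered aromatic ring is not required for the level of inhibition seen with compound 1. The larger ring of compound 2 is what stands apart among the three. Ethyl in place of 5-chloro-1-benzothiophen-3-yl gives an at least 6.4-fold lower number from compound 2 to compound 3 (0.80 log units; beyond the scatter), and this size is only a lower bound: the limit of > 100000 nM in this assay, at which 1 of the 3 values shown sits.

As far as these compounds go, whether an amine, a carboxylic acid or a longer chain on the sulfur would move the number beyond the scatter remains open. So does whether plain phenyl, without the bromine, would behave like 2-bromophenyl.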